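A Single Change on the Chain Carbon Bound to Nitrogen

The compounds below may be only part of what the source reports. "The series", "measured", "known", "first", "only" and "open" are said of these compounds alone.

Measured compounds:
compound 1, `O=c1c2ccccc2c(-c2cccnc2)nn1CC1CCCCC1`: 98%
compound 2, `O=c1c2ccccc2c(-c2cccnc2)nn1S(=O)(=O)c1ccccc1`: 96%

Two compounds share one core and differ only in the group on the nitrogen. In an assay on isolated protein (Oryctolagus cuniculus) with Thromboxane-A synthase (Homo sapiens) as the target, tested at 1 uM (on this read-out higher numbers stand for more inhibition at the one concentration tested (going by the name of the read-out) and lower numbers for less inhibition), compound 1 gives 98%, and compound 2 gives 96%. The two numbers lie within the usual scatter of each other, so compound 1 and compound 2 stand together near the top of the read-out, and neither can be placed ahead of the other.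

Compound 3, `O=c1c2ccccc2c(-c2cccnc2)nn1CCO`, has not yet been tested. It differs from compound 1 by hydroxymethyl in place of cyclohexyl on a saturated chain carbon bound to an aromatic nitrogen. The step is expected to move downward in this assay, by an amount somewhat beyond the scatter, since compound 3 keeps far less of the group that compound 1 carries. Compound 3 is therefore expected to give about 80%, with a range from 50% to 97%, the expected step being a number 18 percentage points lower from compound 1 to compound 3 (beyond the scatter).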

Compound 3, a percentage reported as inhibition, at one concentration (the size of the read-out at that concentration, not a potency): 69%
For compound 3 the middle estimate is 11 percentage points above the measured one; the measured number falls inside the stated range.
By their numbers in this assay, from the lowest: compound 3; then compounds 2 and 1 (each within the scatter of the next).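

In this assay, hydroxymethyl in place of cyclohexyl on a saturated chain carbon bound to an aromatic nitrogen gives a number 29 percentage points lower from compound 1 to compound 3 (beyond the scatter), which shows that the group carried here can move this read-out, something the pair within the scatter of each other could not show. The loss is only partial, since compound 3 still gives 69% at the one concentration tested. Nothing among the data shown accounts for the size of this step.

The change removes the six-membered ring and brings in a hydroxyl at the same time, so the compounds shown leave open which of the two carries the step. A plain ethyl chain, a longer chain ending in hydroxyl or a chain ending in an amine on the same nitrogen would bear on that question.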